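Thiazole for thiophene on a weak dichloroacetamide

This account rests on a few compounds, and the source may have more. Where it says the series, first, only, none or still open, it means among the compounds named here.

Measured in a functional assay on NCI-H460 cells (Homo sapiens) for cytotoxicity, read by MTT assay, with a stated time of 68 h (a higher number here means a weaker inhibitor, a lower number a stronger inhibitor), so far
compound 1 `COc1ccc(-c2cc(NC(=O)C(Cl)Cl)cc(-c3ccc(OC)c(F)c3)c2)cc1F` gives 1760 nM
compound 2 `O=C(Nc1cccc(-c2ccsc2)c1)C(Cl)Cl` gives > 50000 nM as a limit of the assay

Compound 2 has no number, only the limit > 50000 nM and nothing more. Within the data shown here, compound 1 has a number, but it differs from compound 2 in more than one place, so no single measured step is available.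

Compound 3 `O=C(Nc1cccc(-c2nccs2)c1)C(Cl)Cl` has 1,3-thiazol-2-yl in place of thiophen-3-yl on an aromatic carbon and is otherwise the same as compound 2.

Among the measured compounds shown here, the expectation rests on compound 2 at > 50000 nM as the only close neighbour. An estimated step of a number no higher from compound 2 to compound 3 (the limit leaves the size open) is expected to stay within the scatter, in neither direction, in this assay and a report as a limit is likely. For compound 3 the estimate is 50000 nM with an expected range from 20000 nM to 90000 nM in this reading.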

Compound 3, half-maximal inhibitory concentration: > 50000 nM
Compound 3 gave a limit, no number; the forecaster's own chance of this, stated with the estimate: 70%; the middle value lies on the limit itself.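

No step from compound 2 to compound 3 can be read, because both stand at a limit of the assay in this assay: the limit of > 50000 nM in this assay, at which 2 of the 3 values shown sit.

Left open is whether 1,3-thiazol-2-yl in place of thiophen-3-yl changes the read-out at all in this assay, and which of the differences from compound 1 goes with its measured value.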